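The source may hold more compounds than are shown below. What is called first, only, known or untested is meant among the compounds shown, and "the series" means these compounds.

Compound 1 `Cc1c(O)ccc2c1[C@H](Cn1cc(-c3ccc(F)cc3)nn1)[C@@]13CC(=O)[C@@](C)(CC[C@@H]21)C3`: in a functional assay on SW480 cells (Homo sapiens) for cytotoxicity, read by MTT assay, with a stated time of 4 days (a lower number here means a stronger inhibitor, a higher number a weaker inhibitor), compound 1 gives > 20000 nM, a limit of the assay.
Compound 2 `Cc1c(O)ccc2c1[C@H](Cn1cc(-c3ccc(Cl)cc3)nn1)[C@@]13CC(=O)[C@@](C)(CC[C@@H]21)C3`: in this assay compound 2 gives > 20000 nM, a limit of the assay.
Compound 3 `Cc1c(O)ccc2c1[C@H](Cn1cc(-c3ccccn3)nn1)[C@@]13CC(=O)[C@@](C)(CC[C@@H]21)C3`: in this assay compound 3 gives > 20000 nM, a limit of the assay.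

Compound 3 therefore stands at the limit, and the two further values shown sit at the same limit (the limit of > 20000 nM in this assay, at which 3 of the 3 values shown sit). Compound 4 `Cc1c(O)ccc2c1[C@H](Cn1cc(-c3ccc(C(F)(F)F)cc3)nn1)[C@@]13CC(=O)[C@@](C)(CC[C@@H]21)C3` differs from it in one place: 4-(trifluoromethyl)phenyl in place of pyridin-2-yl on an aromatic carbon. The measured steps that bear on this exchange give no readable size: a step that the two limits leave unreadable from compound 1 to compound 3, a step that the two limits leave unreadable from compound 2 to compound 3 and a step that the two limits leave unreadable from compound 1 to compound 2 all run between limits. No step beyond the scatter can be read from them, and another limit is expected. Compound 4 is estimated at 25000 nM in this assay, between 8000 nM and 80000 nM. That estimate means a step that the limit leaves unreadable from compound 3 to compound 4.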

Compound 4, half-maximal inhibitory concentration: > 20000 nM
Compound 4: only a limit was reported (the forecaster's own chance of this, stated with the estimate: 85%); the middle value does not contradict the limit.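

Like compound 1, compound 2 and compound 3, compound 4 sits at a limit, and none of its steps from them can be read: the limit of > 20000 nM in this assay, at which 4 of the 4 values shown sit.
The compounds shown leave open how far any of the four lies beyond that limit, and whether any group at this aromatic carbon would give a measurable value.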